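Cyclohexyl to phenyl on the ring amide nitrogen

The source may report more compounds than this note shows. Statements on the series, on what has been measured and on what is new or still open speak of the compounds shown alone.

Working notes on a small set of sulfonyl thiohydantoin-type analogues, three measured and one pending. Among the measured compounds shown here, compound 1 `Cc1cc(C)n(-c2ccc(S(=O)(=O)N3CC(=O)N(C4CCCCC4)C3=S)cc2)n1` is the only member with a number in a functional assay on the whole organism (blood, strain albino) with Mus musculus as the target, with stated times of 6 days and 4 h, at a dose of 1 mmol/kg by the oral route; on this read-out higher numbers stand for more inhibition at the one dose given (going by the name of the read-out) and lower numbers for less inhibition: compound 1 gives 2%. Compound 2 `C=CCN1C(=O)CN(S(=O)(=O)c2ccc(-n3nc(C(=O)O)cc3C)cc2)C1=S` returns only a limit of the assay, < 1%, and not a number. Compound 3 `CCCN1C(=O)CN(S(=O)(=O)c2ccc(-n3nc(C)cc3C)cc2)C1=S` likewise returns only a limit of the assay, < 1%. For the measured compounds named here, both limits sit at the limit of < 1% in this assay, at which 2 of the 3 values shown sit, so compound 1 stands on the single measured value in the set, with no rival number to rank it against.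

Compound 4 `Cc1cc(C)n(-c2ccc(S(=O)(=O)N3CC(=O)N(c4ccccc4)C3=S)cc2)n1` awaits measurement. Its difference from compound 1 is phenyl in place of cyclohexyl on an amide-type nitrogen in a ring. Going by the values given here, the one measured step that touches the same position is the exchange from compound 1 to compound 3, propyl in place of cyclohexyl on an amide-type nitrogen in a ring, which was a number at least 1 percentage points lower from compound 1 to compound 3 (that floor lies within the scatter) and hence within the scatter. On that basis the exchange of cyclohexyl for phenyl at the same nitrogen is expected to move the read-out by a number 0.5 percentage points lower from compound 1 to compound 4 (within the scatter), that is, no step beyond the scatter in either direction. In this assay compound 4 is therefore expected to give 1.5%, estimated between 0% and 6%, with a fair chance that only a limit is reported.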

Compound 4, a percentage reported as inhibition, in the whole organism at one dose (the size of the read-out at that dose, not a potency): 8%
Estimate against measurement, compound 4: 6.5 percentage points below; the measured number lies above the stated range.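

In this assay, phenyl in place of cyclohexyl on the amide-type nitrogen in the ring gives a number 6 percentage points higher from compound 1 to compound 4 (within the scatter); the two groups match in the counts printed for them and differ in that one ring is aromatic, and on this read-out that exchange does not separate them. Phenyl in place of propyl at the same nitrogen gives a number at least 7 percentage points higher from compound 3 to compound 4 (that floor lies within the scatter), a step read against the limit of the assay held by compound 3, so it sets no order between these two compounds either. Among the compounds shown here, with cyclohexyl, propyl and phenyl now seen at this position, no step among them is printed beyond the scatter, and the series still offers little to rank on: the limit of < 1% in this assay, at which 2 of the 4 values shown sit.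

Open, from the compounds shown here alone, is whether another kind of group on this nitrogen, such as benzyl, a longer chain or a chain ending in an amine, would give a step beyond the scatter in this assay. Also open, going by these compounds, is how compound 1, compound 3 and compound 4 would compare at any other dose, since the read-out gives a size at one dose and not a potency.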